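A methyl group added to the chain of compound 1

The compounds below may be only part of what the source reports. "The series", "measured", "known", "first", "only" and "open" are said of these compounds alone.

Compound 1 `COC(=O)N(C)CC#CCN1CCCC1`: 3 mg/kg
Compound 2 `COC(=O)N(C)CC#CCN(C)C`: 9.7 mg/kg

In a functional assay on the whole organism for agonist activity, with Mus musculus as the target (a higher number here means that more compound is needed for the effect, a lower number that less compound is needed), compound 1 gives 3 mg/kg, the lower of the two numbers, so less of it is needed for the effect. Compound 3 `COC(=O)N(C)C(C)C#CCN1CCCC1` keeps the core of compound 1 and makes one change: methyl in place of hydrogen on a saturated chain carbon bound to an amide-type nitrogen and a triple-bonded carbon. Among the compounds with values here, the only measured step, a 3.2-fold higher number from compound 1 to compound 2 (0.51 log units; beyond the scatter), is modest and puts dimethylamino in place of pyrrolidin-1-yl, which is not the place changed here. It shows that one small change can shift this assay beyond the scatter, but no measurement tests the new methyl. A higher number is the cautious expectation, though its size is uncertain and the range must stay wide. The expected change is a 4.0-fold higher number from compound 1 to compound 3 (0.60 log units; beyond the scatter). Compound 3 is estimated at 12 mg/kg, with an expected range of 3 mg/kg to 50 mg/kg.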

Compound 3, dose for half-maximal effect: 20.9 mg/kg
Estimate against measurement, compound 3: 1.7-fold (0.24 log units) below, within the range that was stated.
By their numbers in this assay, from the lowest: compound 1; then compound 2; then compound 3.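

In this assay the saturated chain carbon bound to an amide-type nitrogen and a triple-bonded carbon turns out to be sensitive: methyl in place of hydrogen, only 1 heavy atom added, gives a 7.0-fold higher number from compound 1 to compound 3 (0.84 log units; beyond the scatter) and so means that more compound is needed for the effect. Within the data shown here, the earlier step changed only the amine group, from pyrrolidin-1-yl to dimethylamino, so this is the first sign that this chain carbon matters too. No measurement available here explains why the methyl has this effect.

As far as these compounds go, whether ethyl, a longer chain, on the same carbon would raise the number further remains open, as does how a single fluorine there would compare with methyl. Also open, from the compounds shown here alone, is whether the methyl would bring a similar step if dimethylamino stood in place of pyrrolidin-1-yl.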